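Two ortho-alkyl groups in place of the methoxy

The source may hold more compounds than are shown below. What is called first, only, known or untested is meant among the compounds shown, and "the series" means these compounds.

Going by the values given here, compound 2 `COc1ccccc1-n1nncc1CN1C(=O)C2(C(C#N)=C(N)Oc3c(N)cc4nc5ccccc5nc4c32)c2ccccc21` gives the only plain number in this set: in a functional assay on MCF7 cells (Homo sapiens) for antiproliferative activity, read by MTT assay, with a stated time of 48 h (a higher number here means a weaker inhibitor, a lower number a stronger inhibitor), compound 2 gives 28900 nM. Compound 1 `Cc1ccccc1-n1nncc1CN1C(=O)C2(C(C#N)=C(N)Oc3c(N)cc4nc5ccccc5nc4c32)c2ccccc21` carries a methyl where compound 2 carries a methoxy, and in this assay compound 1 gives only a limit, > 50000 nM. Among the compounds with values here, the one measured step, an at least 1.7-fold lower number from compound 1 to compound 2 (0.23 log units; that floor lies within the scatter), therefore rests on a limit, as the limit of > 50000 nM in this assay, at which 1 of the 2 values shown sits, shows, so its true size is unknown beyond that floor.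

Compound 3 `CCc1cccc(CC)c1-n1nncc1CN1C(=O)C2(C(C#N)=C(N)Oc3c(N)cc4nc5ccccc5nc4c32)c2ccccc21` is the next step: 2,6-diethylphenyl in place of 2-methoxyphenyl on an aromatic nitrogen. This change bears on the same aryl group as the measured step, but it moves the other way, from an ether back to alkyl groups, and adds a second one. Within the data shown here, the only guide is that the methyl compound sat at the limit while the methoxy compound gave a number; 2,6-diethylphenyl resembles the methyl case more than the methoxy case.

Compound 3 is therefore expected to give a higher number than compound 2, with a 1.6-fold higher number from compound 2 to compound 3 (0.19 log units; within the scatter) as the estimated step, and a fair chance that only a limit is reported. The expected value for compound 3 is 45000 nM, estimated to fall between 18000 nM and 110000 nM.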

Compound 3, half-maximal inhibitory concentration: > 50000 nM
Compound 3: no number, only a limit (the forecaster's own chance of this, stated with the estimate: 45%); middle value at least 1.1-fold (0.04 log units) away from the limit.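

In this assay compound 3 gives only a limit, > 50000 nM. Replacing 2-methoxyphenyl with 2,6-diethylphenyl on the aromatic nitrogen gives an at least 1.7-fold higher number from compound 2 to compound 3 (0.23 log units; that floor lies within the scatter), so this second change at the position again leaves a step known only by its floor, and compound 2 remains the only one of the three with a plain number. Of the aryl groups shown, the two carrying only alkyl groups, in compound 1 and compound 3, both end at the assay's limit and the step between them cannot be read, so the true size of either step from compound 2 stays unknown and no ranking of methyl against diethyl is possible: the limit of > 50000 nM in this assay, at which 2 of the 3 values shown sit.

Whether the plain number of compound 2 goes with the oxygen of its methoxy group stays open, since only one oxygen-bearing aryl group is shown. An ethoxy group, a second methoxy group or an amine on the phenyl ring in this assay would test this, and any of them that gave a plain number would also show how much room the position has.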